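Benzyl on the Saturated Ring of a Sulfamate Amide

The source may hold more compounds than are shown below. What is called first, only, known or untested is meant among the compounds shown, and "the series" means these compounds.

Compound 1 `NS(=O)(=O)Oc1ccc2c(c1)CN(C(=O)c1ccc(N3CCC(N4CCCCC4)CC3)cc1)CC2`: 8.5%
Compound 2 `NS(=O)(=O)Oc1ccc2c(c1)CN(C(=O)c1ccc(N3CCCCC3)cc1)CC2`: 11.5%

For the measured compounds named here, of these two numbers, the one for compound 2 is reached by a number 3 percentage points higher from compound 1 to compound 2 (within the scatter), a gap the scatter covers. Compound 3 `NS(=O)(=O)Oc1ccc2c(c1)CN(C(=O)c1ccc(N3CCC(Cc4ccccc4)CC3)cc1)CC2` differs from compound 2 as follows: benzyl in place of hydrogen on a saturated ring carbon. Going by the values given here, the only measured step also exchanged a group on that saturated ring carbon and moved the read-out by no more than the scatter, so in an assay on HEK293 cells for inhibition of Steryl-sulfatase (Homo sapiens), tested at 0.1 uM (on this read-out higher numbers stand for a stronger effect at the one concentration tested and lower numbers for a weaker effect), the expected step is a number 0.5 percentage points higher from compound 2 to compound 3 (within the scatter), none beyond the scatter. Compound 3 is therefore estimated at 12%, within a range from 0% to 30%.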

Compound 3, a percentage reported as inhibition, at one concentration (the size of the read-out at that concentration, not a potency): 41.4%
Estimate against measurement, compound 3: 29.4 percentage points below, outside the stated range (above it).
By their numbers in this assay, from the lowest: compounds 1 and 2 (each within the scatter of the next); then compound 3.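

In this assay, the saturated ring carbon turns out to respond to the group it carries: benzyl in place of hydrogen gives a number 29.9 percentage points higher from compound 2 to compound 3 (beyond the scatter). Benzyl in place of piperidin-1-yl on the same carbon gives a number 32.9 percentage points higher from compound 1 to compound 3 (beyond the scatter), so a large group there does not by itself raise the number, since compound 1 and compound 2 remain within the scatter of each other. Nothing available accounts for this gain. The compounds shown leave open how phenyl, phenethyl or cyclohexylmethyl on that carbon would compare with benzyl.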